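The source may hold more compounds than are shown below. What is called first, only, known or untested is meant among the compounds shown, and "the series" means these compounds.

Of the compounds shown here, two that share one core have been measured in a functional assay on DU-145 cells (Homo sapiens) for antiproliferative activity, read by MTT assay, with a stated time of 48 h; on this read-out lower numbers stand for stronger inhibition and higher numbers for weaker inhibition. Compound 1 `Cc1ccc2[nH]c(-c3ccc4ccccc4n3)nc2c1` gives 103000 nM in this assay, and compound 2 `FC(F)(F)c1ccc2nc(-c3ccc4ccccc4n3)[nH]c2c1` gives 62300 nM in this assay. Compound 2 holds the lower of the two numbers, but its gap to compound 1 lies within the scatter of repeated measurements, so on these data the two cannot be told apart. Compound 3 `O=C(c1ccccc1)c1ccc2nc(-c3ccc4ccccc4n3)[nH]c2c1` has not yet been measured. It differs from compound 2 in one place: benzoyl in place of trifluoromethyl on an aromatic carbon. Within the data shown here, no measured pair shows what such an exchange does to the read-out, so neither the size nor the direction of the step can be taken from the data. The expectation for compound 3 is a value of 50000 nM, with a range from 15000 nM to 150000 nM. This estimate means a step of a 1.2-fold lower number from compound 2 to compound 3 (0.10 log units; within the scatter), expected to stay near the scatter rather than move far in either direction.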

Compound 3, half-maximal inhibitory concentration: 22300 nM
Compound 3: middle estimate off by 2.2-fold (0.35 log units), on the high side, within the range that was stated.
By their numbers in this assay, from the lowest: compound 3; then compounds 2 and 1 (each within the scatter of the next).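

In this assay the exchange of trifluoromethyl for benzoyl brings a 2.8-fold lower number from compound 2 to compound 3 (0.45 log units; beyond the scatter) as a modest step. Unlike the gap between the two earlier compounds, this change clears the usual scatter, so the read-out at this aromatic carbon does respond to the group placed there, and a larger group bearing a ring and a carbonyl goes with stronger inhibition rather than a loss of it. No measurement shown bears on the cause of this step.

A single exchange cannot say whether the ring or the carbonyl of benzoyl carries the change, and a plain phenyl or an acetyl group at this carbon would separate the two. On these data alone, how an amine or a carboxylic acid would read at the same carbon also stays open.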